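Removing a methylpiperidinyl group from a chemokine receptor antagonist

The source may hold more compounds than are shown below. What is called first, only, known or untested is meant among the compounds shown, and "the series" means these compounds.

Compound 1 `C[C@@H]1CN(c2sc(C(F)(F)F)nc2-c2nc3ccccc3[nH]2)CCN1C(=O)Cn1cccn1`: 191 nM
Compound 2 `Cc1nc(C)n(CC(=O)N2CCN(c3sc(C(F)(F)F)nc3-c3nc4ccc(C5CCN(C)CC5)cc4[nH]3)C[C@H]2C)n1`: 84.7 nM
Compound 3 `C[C@@H]1CN(c2sc(C(F)(F)F)nc2-c2nc3ccccc3[nH]2)CCN1C(=O)Cn1cc(C2CCN(C)CC2)cn1`: 1690 nM

In a functional assay on Venous blood for antagonist activity at C-X-C chemokine receptor type 3 (Homo sapiens), read by flow cytometry, with a stated time of 30 min, in the presence of a further agent that is not named here (a lower number here means a stronger inhibitor, a higher number a weaker inhibitor), compound 2 gives the lowest number of the three measured compounds, so it is the strongest inhibitor among them. Its nearest neighbour is compound 1, which gives 191 nM, and the furthest is compound 3 at 1690 nM.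

Compound 4 `Cc1nc(C)n(CC(=O)N2CCN(c3sc(C(F)(F)F)nc3-c3nc4ccccc4[nH]3)C[C@H]2C)n1` is not yet measured. It differs from compound 2 in one place: hydrogen in place of 1-methylpiperidin-4-yl on an aromatic carbon.

For the measured compounds named here, only one measured step involves this same group: the change from compound 1 to compound 3, where 1-methylpiperidin-4-yl replaced hydrogen on an aromatic carbon, gave an 8.8-fold higher number from compound 1 to compound 3 (0.95 log units; beyond the scatter). That group, however, sits in a different part of the molecule in compound 3 than it does in compound 2, so the step bears on the present change only loosely. Going by the values given here, there is no measured pair that removes the group from the place where compound 2 carries it, and the direction of the effect is therefore open.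

Taking the change as most likely small, compound 4 is expected to give 120 nM, with a range from 40 nM to 400 nM. This expectation corresponds to a step of a 1.4-fold higher number from compound 2 to compound 4 (0.15 log units; within the scatter).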

Compound 4, half-maximal inhibitory concentration in the C-X-C chemokine receptor type 3 assay: 237 nM
Compound 4: the middle estimate sits 2.0-fold (0.30 log units) below what was measured; measured number inside the range.
By their numbers in the C-X-C chemokine receptor type 3 assay, from the lowest: compound 2; then compounds 1 and 4 (each within the scatter of the next); then compound 3.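

For the compounds shown here, in the C-X-C chemokine receptor type 3 assay, taking 1-methylpiperidin-4-yl off the aromatic carbon of the fused ring system gives a 2.8-fold higher number from compound 2 to compound 4 (0.45 log units; beyond the scatter), so at this place the group goes with a stronger inhibitor, which the earlier compounds could not show. The same group therefore acts in opposite directions at its two places in the C-X-C chemokine receptor type 3 assay: the same change on two cores in the C-X-C chemokine receptor type 3 assay, an 8.8-fold higher number (0.95 log units; beyond the scatter) from compound 1 to compound 3 and a 2.8-fold lower number (0.45 log units; beyond the scatter) from compound 4 to compound 2, 25-fold (1.39 log units) apart, beyond the scatter of two such steps With no such group present, putting 3,5-dimethyl-1H-1,2,4-triazol-1-yl in place of 1H-pyrazol-1-yl on the saturated chain carbon gives a 1.2-fold higher number from compound 1 to compound 4 (0.09 log units; within the scatter) in the C-X-C chemokine receptor type 3 assay, so the two cannot be told apart, whereas replacing the larger 4-(1-methylpiperidin-4-yl)-1H-pyrazol-1-yl there gives a 7.1-fold lower number from compound 3 to compound 4 (0.85 log units; beyond the scatter).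

In a physicochemical assay for solubility, in simulated intestinal fluid (a lower number here means a less soluble compound, a higher number a more soluble compound), compound 2 gives > 1020 ug/mL, which is a limit of the assay. As far as these compounds go, compound 4 gives > 850 ug/mL in the physicochemical assay, also a limit, so the step between the two cannot be read, and it stays open whether an open-chain amine on that same aromatic carbon would match the number of the 1-methylpiperidin-4-yl group in the C-X-C chemokine receptor type 3 assay.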